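A methoxy group on the phenyl of compound 3

The source may hold more compounds than are shown below. What is called first, only, known or untested is meant among the compounds shown, and "the series" means these compounds.

Values in a functional assay on K562 cells (Homo sapiens) for cytotoxicity, read by trypan blue exclusion, with a stated time of 96 h; a lower number here means a stronger inhibitor, a higher number a weaker inhibitor:
- compound 1 `COC(=O)CCNc1cc(CS(=O)(=O)/C=C/c2c(OC)cc(OC)cc2OC)ccc1OC`: 1000 nM
- compound 2 `COC(=O)C(C)(C)Nc1cc(CS(=O)(=O)/C=C/c2c(OC)cc(OC)cc2OC)ccc1OC`: 800 nM
- compound 3 `COC(=O)C(Nc1cc(CS(=O)(=O)/C=C/c2c(OC)cc(OC)cc2OC)ccc1OC)c1ccccc1`: 30 nM

Compound 3 has the lowest number of the three, 30 nM, and it is the strongest inhibitor of the set in this assay. The next compound, compound 4 `COC(=O)C(Nc1cc(CS(=O)(=O)/C=C/c2c(OC)cc(OC)cc2OC)ccc1OC)c1ccc(OC)cc1`, differs from it in one place: methoxy in place of hydrogen on an aromatic carbon. Methoxy stands in place of hydrogen on an aromatic carbon, para to a large group, turning phenyl into 4-methoxyphenyl.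

Among the measured compounds shown here, no measured step tests a substituent on this phenyl. The nearest evidence concerns the group on the nitrogen. There, a 1.3-fold lower number from compound 1 to compound 2 (0.10 log units; within the scatter), while a 33-fold lower number from compound 1 to compound 3 (1.52 log units; beyond the scatter) and a 27-fold lower number from compound 2 to compound 3 (1.43 log units; beyond the scatter). These steps show that changes to that group can move the number strongly in this assay, but they do not show what a methoxy on the phenyl does. With no direct evidence for a shift in either direction, no step beyond the scatter is expected, and the range is kept wide. The expected outcome is no change at the digits printed from compound 3 to compound 4 (within the scatter). Compound 4 is estimated at 30 nM, with an expected range from 10 nM to 100 nM.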

Compound 4, half-maximal inhibitory concentration: 150 nM
Compound 4: middle estimate off by 5.0-fold (0.70 log units), on the low side, outside the stated range (above it).
By their numbers in this assay, from the lowest: compound 3; then compound 4; then compounds 2 and 1 (each within the scatter of the next).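

In this assay, among the compounds shown here, the phenyl of compound 3 turns out to be sensitive to substitution, which the earlier steps on the group on the nitrogen could not show: methoxy in place of hydrogen, para to a large group, gives a 5.0-fold higher number from compound 3 to compound 4 (0.70 log units; beyond the scatter). The change from phenyl to 4-methoxyphenyl therefore gives back part of the low number seen with compound 3, but not all of it, since compound 4 at 150 nM still lies well below compound 2 at 800 nM. No measurement available here bears on why this single methoxy raises the number.

From the compounds shown here alone, with only one substituent at one place on this phenyl, it remains open whether the rise is specific to methoxy or would also follow from another group there, such as a fluorine atom, a hydroxyl or a methyl. Also open, going by these compounds, is whether methoxy would have the same effect at another carbon of the phenyl, and whether a carboxylic acid in place of the methyl ester would alter the standing of compound 3 and compound 4 relative to each other.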